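Swapping fluoro for tert-butyl in a growth-inhibition series

The source may report more compounds than this note shows. Statements on the series, on what has been measured and on what is new or still open speak of the compounds shown alone.

In a functional assay on A-375 cells (Homo sapiens) for inhibition, read by CCK-8 assay, with a stated time of 72 h, tested at 2 uM (a higher number here means more inhibition of growth at the concentration tested, a lower number less inhibition of growth), compound 1 (`COc1ccc(SCc2ccc(/C=C/C(=O)Nc3ccccc3N)cc2)cc1OC`) gives 46%, compound 2 (`CCc1ccc(SCc2ccc(/C=C/C(=O)Nc3ccccc3N)cc2)cc1`) gives 5.27% and compound 3 (`Nc1ccccc1NC(=O)/C=C/c1ccc(CSc2ccc(F)cc2)cc1`) gives 28.8%, the middle of the three numbers. Compound 4 (`CC(C)(C)c1ccc(SCc2ccc(/C=C/C(=O)Nc3ccccc3N)cc2)cc1`) carries tert-butyl in place of fluoro on an aromatic carbon, para to a large group: tert-butyl in place of fluoro on an aromatic carbon. Within the data shown here, no tert-butyl compound has been measured, so the nearest evidence is ethyl against fluoro at that place, a number 23.5 percentage points higher from compound 2 to compound 3 (beyond the scatter), a modest step that runs opposite to this change. The large a number 40.7 percentage points lower from compound 1 to compound 2 (beyond the scatter) also ends at the ethyl compound, while a number 17.2 percentage points lower from compound 1 to compound 3 (beyond the scatter) is modest. A modest fall is therefore expected, an estimated a number 16.8 percentage points lower from compound 3 to compound 4 (beyond the scatter). The expected value for compound 4 is 12%, with an estimated range of 0% to 30%.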

Compound 4, percent growth inhibition at one concentration: 38.4%
Compound 4: middle estimate off by 26.4 percentage points, on the low side; measured number outside the range, above it.
By their numbers in this assay, from the lowest: compound 2; then compounds 3, 4 and 1 (each within the scatter of the next, the first and the last beyond it).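

In this assay, tert-butyl and fluoro on this aromatic carbon are not separated, at a number 9.6 percentage points higher from compound 3 to compound 4 (within the scatter). The ethyl compound is the one that falls away, at a number 33.1 percentage points higher from compound 2 to compound 4 (beyond the scatter), so its low number does not extend to tert-butyl, the other alkyl group shown at this place. The 4-(tert-butyl)phenyl on sulfur also stays level with 3,4-dimethoxyphenyl, at a number 7.6 percentage points lower from compound 1 to compound 4 (within the scatter). Nothing available explains the gap between ethyl and tert-butyl. From the compounds shown here alone, whether methyl, a longer chain such as propyl, or an amine at this place would follow ethyl or tert-butyl remains open.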